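The compounds below may be only part of what the source reports. "The series", "measured", "known", "first", "only" and "open" are said of these compounds alone.

In a functional assay on WiDr cells (Homo sapiens) for inhibition, read by sulforhodamine B assay, with a stated time of 48 h (a higher number here means a weaker inhibitor of growth, a lower number a stronger inhibitor of growth), compound 2 `CCOC(=[Se])Nc1ccc2c(C)cc(=O)oc2c1` gives > 100000 nM, which is a limit and not a number. Compound 1 `COC(=[Se])Nc1ccc2c(C)cc(=O)oc2c1` gives > 100000 nM, also a limit. Compound 2 thus stands at the limit of > 100000 nM in this assay, at which 2 of the 3 values shown sit. Compound 3 `CCCCNC(=[Se])Nc1ccc2c(C)cc(=O)oc2c1` gives a true number, 3800 nM. Compound 4 `Cc1cc(=O)oc2cc(NC(=[Se])Nc3ccccc3)ccc12` has anilino in place of ethoxy on a saturated chain carbon bound to a nitrogen on an aromatic ring. The nearest measured changes also bring in a nitrogen-linked group, butylamino. They are an at least 26-fold lower number from compound 2 to compound 3 (1.42 log units; beyond the scatter) and an at least 26-fold lower number from compound 1 to compound 3 (1.42 log units; beyond the scatter), both large. A large fall in the number is therefore expected in this assay, and the estimated change is an at least 20-fold lower number from compound 2 to compound 4 (1.30 log units; beyond the scatter). For compound 4 the estimated value is 5000 nM, with an expected range of 1500 nM to 20000 nM.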

Compound 4, concentration for 50% growth inhibition: 34000 nM
Estimate against measurement, compound 4: 6.8-fold (0.83 log units) below, outside the stated range (above it).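

In this assay, among these compounds, anilino in place of ethoxy gives an at least 2.9-fold lower number from compound 2 to compound 4 (0.46 log units; beyond the scatter) and anilino in place of methoxy gives an at least 2.9-fold lower number from compound 1 to compound 4 (0.46 log units; beyond the scatter) so butylamino is not the only nitrogen-linked group here that lowers the number. Phenyl in place of butyl on the amine nitrogen gives an 8.9-fold higher number from compound 3 to compound 4 (0.95 log units; beyond the scatter) and this shows, as the earlier compounds could not, that the group carried on that nitrogen matters. From the compounds shown here alone, the size of the first of these steps stays open-ended, since compound 2 gives a limit and not a number: the limit of > 100000 nM in this assay, at which 2 of the 4 values shown sit.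

Going by these compounds, whether benzylamino or a shorter chain such as ethylamino would fall nearer compound 3 or compound 4 remains open.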